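A few compounds are considered here, and "the series" means these few. Any claim that something is new, unique, unknown or untested is made for them only; others in the source may bear on it.

Measured in a functional assay on HepG2 cells (Homo sapiens) for antiproliferative activity, read by MTT assay; on this read-out lower numbers stand for stronger inhibition and higher numbers for weaker inhibition:

Compound 1, `O=C1N=C(N2CCC[C@H]2C(=O)Nc2ccc3ncnc(Nc4cccc(Cl)c4)c3c2)S/C1=C/c1ccc(-c2ccccc2)cc1`, gives 15400 nM.
Compound 2, `O=C1N=C(N2CCC[C@H]2C(=O)Nc2ccc3ncnc(Nc4cccc(Cl)c4)c3c2)S/C1=C/c1cccc(Br)c1`, gives 21300 nM.

Among the measured compounds shown here, compound 2 has the highest number of the two measured in this assay, yet its nearest neighbour is compound 1, and the only recorded step, a 1.4-fold higher number from compound 1 to compound 2 (0.14 log units; within the scatter), stays within the usual scatter of repeated measurements. The two compounds therefore cannot be told apart on activity.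

Compound 3, `O=C1N=C(N2CCC[C@H]2C(=O)Nc2ccc3ncnc(Nc4cccc(Cl)c4)c3c2)S/C1=C/c1ccccc1[N+](=O)[O-]`, differs from compound 2 in one place: 2-nitrophenyl in place of 3-bromophenyl on a double-bonded chain carbon bound to a double-bonded ring carbon. For the measured compounds named here, no measured step exchanges a 3-bromophenyl for a 2-nitrophenyl, so the only guide is the step from compound 1 to compound 2, which shows that swapping one aryl group for another on this double-bonded chain carbon left the number essentially unchanged. On that basis the step of a 1.1-fold lower number from compound 2 to compound 3 (0.03 log units; within the scatter) is expected to fall within the scatter, with no clear direction.

Compound 3 is accordingly estimated at 20000 nM in this assay, with a plausible range from 8000 nM to 50000 nM.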

Compound 3, half-maximal inhibitory concentration: 32500 nM
Compound 3: the middle estimate sits 1.6-fold (0.21 log units) below what was measured, within the range that was stated.
By their numbers in this assay, from the lowest: compounds 1, 2 and 3 (each within the scatter of the next, the first and the last beyond it).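

In this assay, the step (a 1.5-fold higher number from compound 2 to compound 3 (0.18 log units; within the scatter)) stays within the scatter, so 2-nitrophenyl and 3-bromophenyl cannot be told apart at this double-bonded chain carbon. Among the compounds shown here, the other new step (a 2.1-fold higher number from compound 1 to compound 3 (0.32 log units; beyond the scatter)) is the first at this position to pass beyond the scatter, if only modestly, so the choice of aryl group here can make a small measurable difference, at least between 2-nitrophenyl and 4-phenylphenyl, while compound 2 cannot be separated from either compound 1 or compound 3. No supporting measurement is available to account for this small gap between compound 1 and compound 3.

As far as these compounds go, the groups at this carbon in all three compounds are aryl rings, so the effect of a quite different kind of group there, such as an amine, a carboxylic acid or a longer alkyl chain, remains open. The three rings also differ both in their substituent and in where it sits, which leaves the contribution of each of these two features unresolved.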